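The compounds below may be only part of what the source reports. "The series", "measured", "known", "first", "only" and "open" are said of these compounds alone.

Measured so far in an assay on CHO cells for displacement of a labelled ligand from adenosine receptor A3 (Homo sapiens), read by scintillation counting, with a stated time of 120 min, tested at 1 uM; a higher number here means more inhibition at the concentration tested (going by the name of the read-out), a lower number less inhibition:
- compound 1 `CCOc1ccc(-c2c(C#N)c(N)nc(SCc3ccn[nH]3)c2C#N)cc1`: 18%
- compound 2 `N#Cc1c(N)nc(SCn2cncn2)c(C#N)c1-c1ccc(OCC2CC2)cc1`: 1%
- compound 3 `N#Cc1c(N)nc(SCc2cnc[nH]2)c(C#N)c1-c1ccc(OCC2CC2)cc1`: 1%

Compound 1 gives the highest of the three numbers in this assay; compound 2 and compound 3 both stand lower by the same margin, beyond the scatter. For the measured compounds named here, the only measured one-point step, no change at the digits printed from compound 2 to compound 3 (within the scatter), is a swap of one five-membered heteroaryl for another on the same position and leaves the number unchanged within the scatter; both of those compounds also differ from compound 1 elsewhere, so it bears on the present step only loosely.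

Compound 4 `CCOc1ccc(-c2c(C#N)c(N)nc(SCC(N)=O)c2C#N)cc1` is the target. Its change from compound 1 reads (carbamoyl in place of 1H-pyrazol-5-yl on a saturated chain carbon bound to a sulfur). Going by the values given here, no measured pair covers a ring-to-open-chain change at this position, so the expectation rests on the series sitting low overall with compound 1 alone showing the modest 18%. A step of a number 12 percentage points lower from compound 1 to compound 4 (beyond the scatter) is expected, that is a small downward drift, at the edge of the scatter. Compound 4 is estimated at 6%, plausibly between -5% and 18%.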

Compound 4, a percentage reported as inhibition, at one concentration (the size of the read-out at that concentration, not a potency): 20%
Estimate against measurement, compound 4: 14 percentage points below; measured number outside the range, above it.
By their numbers in this assay, from the lowest: compounds 2 and 3 (each within the scatter of the next); then compounds 1 and 4 (each within the scatter of the next).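

Within this assay carbamoyl in place of 1H-pyrazol-5-yl on a saturated chain carbon bound to a sulfur gives a number 2 percentage points higher from compound 1 to compound 4 (within the scatter) and is the first ring-to-open-chain change read at this position. The number seen with compound 1 therefore does not depend on the five-membered aromatic ring: an open group with no ring and fewer heavy atoms, but the same counts of hydrogen-bond donors and acceptors, serves equally in this read-out. No measured evidence is at hand on why the number holds across this change.

On these data alone, it remains open whether a carboxylic acid, an amine or a longer chain at the same place would also hold the number. As far as these compounds go, both numbers are single-concentration readings, so any difference in potency between compound 1 and compound 4 also remains open.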